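The source may report more compounds than this note shows. Statements on the series, on what has been measured and on what is new or still open speak of the compounds shown alone.

Measured compounds in an ADME assay on MT4 cells (Homo sapiens) for cytotoxicity, read by MTT assay, with a stated time of 4 days; a higher number here means that more compound is tolerated, a lower number that less compound is tolerated:
Compound 1 `COc1ccccc1Oc1nc(Nc2ccc(C#N)cc2)nc2ccccc12` gives 150000 nM.
Compound 2 `Cc1cc(Br)cc(Br)c1Oc1nc(Nc2ccc(C#N)cc2)nc2ccccc12` gives 150000 nM.
Compound 3 `Cc1cc(C)c(Oc2nc(Nc3ccc(C#N)cc3)nc3ccccc23)c(C)c1` gives > 34000 nM, which is a limit of the assay and not a number.

Compound 1 stands level with compound 2 at the digits shown: the step of no change at the digits printed from compound 1 to compound 2 (within the scatter) is within the scatter. The step that the limit leaves unreadable from compound 1 to compound 3 cannot be sized because the value of compound 3 is a limit (the limit of > 34000 nM in this assay, at which 1 of the 3 values shown sits). The step that the limit leaves unreadable from compound 2 to compound 3 is likewise not readable.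

The unmeasured compound 4 `N#Cc1ccc(Nc2nc(Oc3c(Cl)cc(Cl)cc3Cl)c3ccccc3n2)cc1` differs from compound 1 by 2,4,6-trichlorophenyl in place of 2-methoxyphenyl on an oxygen on an aromatic ring. Going by the values given here, the closest measured step is the one from compound 1 to compound 2, where a halogenated phenyl on the same oxygen replaced the 2-methoxyphenyl and no change at the digits printed from compound 1 to compound 2 (within the scatter) showed no change beyond the scatter. Compound 3, with a 2,4,6-trimethylphenyl in the same place, gives only a limit, so it adds no readable size. On these grounds no step beyond the scatter is expected in this assay from compound 1 to compound 4, and the step is estimated as a 1.3-fold lower number from compound 1 to compound 4 (0.10 log units; within the scatter). Compound 4 is therefore expected to come in at about 120000 nM, between 40000 nM and 300000 nM, with a fair chance that the assay reports only a limit.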

Compound 4, half-maximal cytotoxic concentration: 56000 nM
The estimate for compound 4 lay 2.1-fold (0.33 log units) above the measured number; measured number inside the range.
By their numbers in this assay, from the lowest: compound 4; then compounds 1 and 2 (each within the scatter of the next).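

In this assay, this place on the oxygen proves able to move the number: 2,4,6-trichlorophenyl in place of 2-methoxyphenyl gives a 2.7-fold lower number from compound 1 to compound 4 (0.43 log units; beyond the scatter) as a modest step, whereas the earlier halogenated replacement gave no change at the digits printed from compound 1 to compound 2 (within the scatter) and stayed level. The two halogenated groups do not read alike either, with 2,4,6-trichlorophenyl in place of 2,4-dibromo-6-methylphenyl giving a 2.7-fold lower number from compound 2 to compound 4 (0.43 log units; beyond the scatter) as a step of the same modest size, so across compounds 1, 2 and 4 the presence of halogen on the phenyl ring does not by itself set the number, and compound 2 goes against any such rule. Nothing available accounts for the lower number of compound 4.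

Compound 3 gives > 34000 nM in this assay, which is a limit of the assay and not a number, so every step to or from compound 3 stays unreadable and the comparison of 2,4,6-trichlorophenyl with 2,4,6-trimethylphenyl remains open: the limit of > 34000 nM in this assay, at which 1 of the 4 values shown sits.
On these data alone, how an amine or a carboxylic acid on the phenyl ring at this oxygen would read in this assay also stays open, as does the effect of a single chlorine in place of the three.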